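The source may report more compounds than this note shows. Statements on the series, on what has been measured and on what is new or still open speak of the compounds shown alone.

Measured compounds:
- compound 1 `C=CC(=O)Nc1ccc(Cn2nc(-c3ccc(Oc4ccccc4)cc3)cc2C(=O)O)cc1`
- compound 2 `C/C=C/C(=O)Nc1ccc(Cn2nc(-c3ccc(Oc4ccccc4)cc3)cc2C(=O)O)cc1`
- compound 3 `C/C=C/C(=O)Nc1ccc(Cn2nc(-c3ccc(Oc4ccccc4)cc3)cc2CO)cc1`

In a functional assay on Maver1 cells (Homo sapiens) for inhibition, read by luminescence and CellTiter-Glo, with a stated time of 72 h (on this read-out higher numbers stand for weaker inhibition and lower numbers for stronger inhibition), compound 1 gives only a limit of the assay, > 60000 nM. Compound 2 likewise gives only a limit, > 60000 nM. Within the data shown here, compound 3 is the one compound with a number in this assay, 48400 nM.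

Compound 1 and compound 2 differ by vinyl in place of prop-1-en-1-yl on a carbonyl carbon. Both sit at the limit of > 60000 nM in this assay, at which 2 of the 3 values shown sit, so this step is a step that the two limits leave unreadable from compound 2 to compound 1. Compound 2 and compound 3 differ in their cores by hydroxymethyl in place of carboxy on an aromatic carbon, and the step is an at least 1.2-fold lower number from compound 2 to compound 3 (0.09 log units; that floor lies within the scatter).

Compound 4 `C=CC(=O)Nc1ccc(Cn2nc(-c3ccc(Oc4ccccc4)cc3)cc2CO)cc1` is still to be measured. It differs from compound 3 by vinyl in place of prop-1-en-1-yl on a carbonyl carbon, the same change as from compound 2 to compound 1. Because that earlier step is a step that the two limits leave unreadable from compound 2 to compound 1, no size can be carried over. Compound 4 is expected to stay close to compound 3, an estimated 1.1-fold higher number from compound 3 to compound 4 (0.03 log units; within the scatter), giving an estimate of 52000 nM, between 25000 nM and 110000 nM.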

Compound 4, half-maximal inhibitory concentration: 7000 nM
Compound 4: the middle estimate sits 7.4-fold (0.87 log units) above what was measured, and the stated range ends above it.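

In this assay, putting vinyl in place of prop-1-en-1-yl on the core with hydroxymethyl gives a 6.9-fold lower number from compound 3 to compound 4 (0.84 log units; beyond the scatter). Going by these compounds, putting hydroxymethyl in place of carboxy on the core with the vinyl amide gives an at least 8.5-fold lower number from compound 1 to compound 4 (0.93 log units; beyond the scatter), but whether this change does more here than on the core with the prop-1-en-1-yl amide stays unknown: the same change on two cores in this assay, an at least 1.2-fold lower number (0.09 log units; that floor lies within the scatter) from compound 2 to compound 3 and an at least 8.5-fold lower number (0.93 log units; beyond the scatter) from compound 1 to compound 4; the limit leaves it open whether they differ. The vinyl step on the carboxy core cannot be read, so these compounds do not show that the vinyl change carries from one core to the other: the limit of > 60000 nM in this assay, at which 2 of the 4 values shown sit.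

On these data alone, it remains open whether the vinyl change would act the same way with an amine or a methyl ester in place of hydroxymethyl. As far as these compounds go, how a longer chain on the carbonyl carbon would compare is also open.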